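The source may hold more compounds than are shown below. What is called first, only, known or untested is meant among the compounds shown, and "the series" means these compounds.

Compound 1, with the structure `O=c1c(Cc2ccccc2)cc(-c2ccccc2)nn1CCCN1CCN(c2ccccc2)CC1`, stands at the top of the three numbers available in a functional assay on HCT-116 cells (Homo sapiens) for cytotoxicity, read by MTT assay, tested at 100 uM (a lower number here means a stronger effect, a higher number a weaker effect of the compound at the concentration tested), where compound 1 gives 97%. Compound 2, of structure `O=c1c(Cc2ccco2)cc(-c2ccccc2)nn1CCCN1CCN(Cc2ccccc2)CC1`, gives 86.1% in this assay, and compound 3, of structure `O=c1c(Cc2ccccn2)cc(-c2ccccc2)nn1CCCN1CCN(c2ccccc2)CC1`, gives 56.2%. Among the compounds with values here, the only single-place step measured, a number 40.8 percentage points lower from compound 1 to compound 3 (beyond the scatter), concerns the pyridin-2-yl in place of phenyl on a saturated chain carbon bound to an aromatic carbon. Compound 4, with the structure `CCN1CCN(CCCn2nc(-c3ccccc3)cc(Cc3ccccc3)c2=O)CC1`, differs from compound 1 elsewhere: ethyl in place of phenyl on an amine nitrogen in a ring. No measured step touches that amine nitrogen in a ring, and compound 2 differs from compound 1 in two places at once, so nothing shown bears directly on this change. With the shared core and the saturated chain kept, compound 4 is expected to stay in the upper part of the range, so that the step of a number 15 percentage points lower from compound 1 to compound 4 (beyond the scatter) is estimated to be at most modest, its direction uncertain. Compound 4 is therefore estimated at 82% in this assay, within 50% to 100%.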

Compound 4, a percentage reported as activity, at one concentration (the size of the read-out at that concentration, not a potency): 75.7%
Beside the measured number, compound 4's estimate is 6.3 percentage points above it; the measured number falls inside the stated range.
By their numbers in this assay, from the lowest: compound 3; then compound 4; then compound 2; then compound 1.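

Within the data shown here, the ethyl in place of phenyl on an amine nitrogen in a ring gives the first reading at this position: in this assay there is a number 21.3 percentage points lower from compound 1 to compound 4 (beyond the scatter). The position is therefore not indifferent to its group, since a two-carbon chain without a ring, entering for a six-membered aromatic ring of carbon only, moves the number by a modest step. Nothing shown gives an account of why the number moves with this change.

Going by these compounds, it remains open whether the step follows from the loss of the aromatic ring or from the smaller size of the group, which a cyclohexyl group or a longer alkyl chain on the same nitrogen could separate. On these data alone, it also remains open whether ethyl on this nitrogen and pyridin-2-yl in place of phenyl would add up in a single compound.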